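This account rests on a few compounds, and the source may have more. Where it says the series, first, only, none or still open, it means among the compounds named here.

Compound 3 `CN1CCN(c2ccc(Nc3nc(-c4cccc(NC(=O)c5ccccc5)c4)sc3C(=O)O)cc2)CC1` is reported in a functional assay on Ramos cells (Homo sapiens) for antiproliferative activity, read by CCK-8 assay, with a stated time of 72 h (a lower number here means a stronger inhibitor, a higher number a weaker inhibitor), only as "not determined" (no result reported), so its standing among the measured numbers cannot be placed. Compound 4 `CN1CCN(c2ccc(Nc3nc(-c4cccc(NC(=O)c5ccccc5F)c4)sc3C(=O)O)cc2)CC1` differs from it by fluoro in place of hydrogen on an aromatic carbon. Among the measured compounds shown here, the one measured step of the same kind is a 12-fold lower number from compound 1 to compound 2 (1.09 log units; beyond the scatter). In this assay compound 1 `CCOC(=O)c1sc(-c2cccc(NC(=O)c3ccccc3)c2)nc1Nc1ccc(N2CCN(C)CC2)cc1` gives 24800 nM, while compound 2 `CCOC(=O)c1sc(-c2cccc(NC(=O)c3ccccc3F)c2)nc1Nc1ccc(N2CCN(C)CC2)cc1` gives 2000 nM. For the measured compounds named here, compound 3 and compound 4 carry the free acid where the two measured compounds carry the ethyl ester, and no measured step shows how that exchange acts in this assay. A step of similar size toward a lower number is therefore expected for compound 4, with wide uncertainty, since no value for compound 3 anchors it. Compound 4 is expected to give about 4000 nM, within 500 nM to 40000 nM.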

Compound 4, half-maximal inhibitory concentration: 6300 nM
Compound 4: the middle estimate sits 1.6-fold (0.20 log units) below what was measured, and the stated range covers the measured number.
By their numbers in this assay, from the lowest: compound 2; then compound 4; then compound 1.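

With the 2-fluorophenyl group held in place, exchanging the ethyl ester for the free acid gives a 3.2-fold higher number from compound 2 to compound 4 (0.50 log units; beyond the scatter) in this assay. Among the compounds shown here, this is the first measured reading of that exchange, and it shows that the position carries either group with a modest shift in the number. No evidence on hand accounts for this shift.

From the compounds shown here alone, the step from compound 3 to compound 4 cannot be read, so whether fluoro acts on the acid as it does on the ester remains open. Going by these compounds, how a carboxamide or a hydroxymethyl group would read at this position also remains open.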